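From Compound 2 to Compound 3 in the Writhing Test

The source may hold more compounds than are shown below. What is called first, only, known or untested is meant among the compounds shown, and "the series" means these compounds.

Compound 1: `Cc1ccc(-c2cc(C)n(S(=O)(=O)Oc3ccccc3)n2)cc1` — 50.7%
Compound 2: `CCc1ccc(-c2cc(C)n(S(=O)(=O)Oc3ccccc3)n2)cc1` — 48.1%
Compound 3: `Cc1cccc(-c2cc(C)n(S(=O)(=O)Oc3ccccc3)n2)c1` — not yet measured

In a functional assay on the whole organism for inhibition, with Mus musculus as the target, in the writhing test, with stated times of 3 days and 20 min, at a dose of 30 mg/kg by the oral route (a higher number here means more inhibition at the dose given (going by the name of the read-out), a lower number less inhibition), compound 2 gives 48.1%. Going by the values given here, of the two numbers in hand this is the lower, but the only neighbour, compound 1, stands a number 2.6 percentage points lower from compound 1 to compound 2 (within the scatter), so the two compounds cannot be told apart on this read-out. Compound 3 differs from compound 2 in one place: 3-methylphenyl in place of 4-ethylphenyl on an aromatic carbon. Among the compounds with values here, the one measured step that bears on this is the one from compound 1 to compound 2, which added a methyl on the saturated chain carbon and moved the number by a number 2.6 percentage points lower from compound 1 to compound 2 (within the scatter). Part of the new change undoes that addition; for the shift of the methyl to another position of the ring there is no measured step. Within the data shown here, since the only comparable step lay within the scatter, no movement beyond the scatter is expected in this assay. Compound 3 is expected to give about 49%, between 35% and 63%. That expectation amounts to an estimated step of a number 0.9 percentage points higher from compound 2 to compound 3 (within the scatter).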

Compound 3, a percentage reported as inhibition, in the whole organism at one dose (the size of the read-out at that dose, not a potency): 43.8%
Compound 3: the middle estimate sits 5.2 percentage points above what was measured; measured number inside the range.
By their numbers in this assay, from the lowest: compounds 3, 2 and 1 (each within the scatter of the next).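

In this assay, putting 3-methylphenyl in place of 4-ethylphenyl on the aromatic carbon gives a step (a number 4.3 percentage points lower from compound 2 to compound 3 (within the scatter)), and putting it in place of 4-methylphenyl gives another (a number 6.9 percentage points lower from compound 1 to compound 3 (within the scatter)). The earlier pair had varied only the chain on a 4-substituted phenyl, whereas these steps show that moving the methyl to another ring position also stays within the scatter, so the three aryl groups cannot be told apart on this read-out at this single dose. Nothing at hand speaks to what lies behind these numbers.

From the compounds shown here alone, all three groups are phenyl rings bearing a small saturated chain, so it remains open whether an amine, a carboxylic acid or a longer chain such as butyl on that ring would move the number beyond the scatter. Going by these compounds, it also remains open whether the three compounds would separate at another dose.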